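Replacing the Nitro Group: an Expected Loss of Solubility

A few compounds are considered here, and "the series" means these few. Any claim that something is new, unique, unknown or untested is made for them only; others in the source may bear on it.

Three sugar-bearing compounds sharing one core have been measured in a physicochemical assay for solubility, measured as kinetic solubility, with a stated time of 15 h, at pH 7.4; a higher number here means a more soluble compound, a lower number a less soluble compound. Compound 2 `O=[N+]([O-])c1ccc(-c2ccc(O[C@H]3O[C@H](CO)[C@@H](O)[C@H](O)[C@@H]3O)c(Cl)c2)cc1` gives 117 ug/mL, the highest of the three numbers. Compound 1 `OC[C@H]1O[C@H](Oc2ccc(-c3ccc(C(F)(F)F)cc3)cc2Cl)[C@@H](O)[C@@H](O)[C@@H]1O` gives 22 ug/mL, and compound 3 `OC[C@H]1O[C@H](Oc2ccc(-c3ccccc3)cc2Cl)[C@@H](O)[C@@H](O)[C@@H]1O` gives 5.5 ug/mL. Compound 4 `Cc1ccccc1-c1ccc(O[C@H]2O[C@H](CO)[C@@H](O)[C@H](O)[C@@H]2O)c(Cl)c1` has not yet been measured; it differs from compound 2 in one place: 2-methylphenyl in place of 4-nitrophenyl on an aromatic carbon. Within the data shown here, two measured steps bear on this change: a 21-fold lower number from compound 2 to compound 3 (1.33 log units; beyond the scatter) and, read in reverse, a 5.3-fold higher number from compound 1 to compound 2 (0.73 log units; beyond the scatter); in both, taking away the nitro group lowered the number well beyond the scatter. A large downward step is therefore expected in this assay, namely a 15-fold lower number from compound 2 to compound 4 (1.17 log units; beyond the scatter). Compound 4 is estimated at 8 ug/mL, within a range from 2.5 ug/mL to 25 ug/mL.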

Compound 4, solubility: 135 ug/mL
Compound 4: middle estimate off by 17-fold (1.23 log units), on the low side; the measured number lies above the stated range.
By their numbers in this assay, from the lowest: compound 3; then compound 1; then compounds 2 and 4 (each within the scatter of the next).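

In this assay, taking away the nitro group does not by itself bring the number down: 2-methylphenyl in its place gives a 1.2-fold higher number from compound 2 to compound 4 (0.06 log units; within the scatter) and so stands level with the nitro compound. A single methyl in place of hydrogen gives a 25-fold higher number from compound 3 to compound 4 (1.39 log units; beyond the scatter) as the largest step in this set, so one small group on this ring can decide the outcome. No measurement shown gives a reason for either step.

On these data alone, whether an ethyl or a methoxy group in place of that methyl would hold the number up stays open. So does whether a methyl elsewhere on the ring would do the same.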